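This account rests on a few compounds, and the source may have more. Where it says the series, first, only, none or still open, it means among the compounds named here.

Compound 1 `Cc1ccc(S(=O)(=O)c2cnc3c(F)cccc3c2N2CCC(C)CC2)cc1` and compound 2 `COc1cccc(S(=O)(=O)c2cnc3ccc(F)cc3c2N2CCC(C)CC2)c1` were both tested in an assay on isolated protein for displacement of a labelled ligand from metabotropic glutamate receptor 5 (Homo sapiens), with a stated time of 60 min, tested at 1 uM; a higher number here means more inhibition at the concentration tested (going by the name of the read-out), a lower number less inhibition. In this assay compound 1 gives 93%, and compound 2 gives 90%; the two numbers lie within the usual scatter of each other, so neither compound stands apart. Compound 3 `CC1CCN(c2c(S(=O)(=O)c3ccc(F)cc3)cnc3c(F)cccc23)CC1` has not yet been measured. It differs from compound 1 by fluoro in place of methyl on an aromatic carbon. Among the measured compounds shown here, with no measured step of this kind at hand, the step from compound 1 to compound 3 is expected to be small, in either direction and not beyond the scatter: a number 5 percentage points lower from compound 1 to compound 3 (within the scatter). Compound 3 is therefore estimated at 88%, with a range from 70% to 98%.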

Compound 3, a percentage reported as inhibition, at one concentration (the size of the read-out at that concentration, not a potency): 26%
Compound 3: the middle estimate sits 62 percentage points above what was measured, outside the stated range (below it).
By their numbers in this assay, from the lowest: compound 3; then compounds 2 and 1 (each within the scatter of the next).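

In this assay, fluoro in place of methyl, para to a large group, gives a number 67 percentage points lower from compound 1 to compound 3 (beyond the scatter), so this position is sensitive to a change of a single heavy atom. Among the compounds shown here, compounds 1 and 2 differ in more than one place and offered no step, so they could not show this. Nothing measured here accounts for the drop.

On these data alone, it remains open whether a chloro, ethyl or trifluoromethyl group at this position would stay near compound 1 or fall towards compound 3. As far as these compounds go, whether the step would be as large on the core of compound 2 is also open.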